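The source may hold more compounds than are shown below. What is called first, only, known or untested is meant among the compounds shown, and "the series" means these compounds.

In an assay on cell membranes for binding affinity to 2-oxoglutarate receptor 1 (Rattus norvegicus), read by radioligand binding (on this read-out lower numbers stand for stronger inhibition and higher numbers for weaker inhibition), compound 1 `CCCCCCNC(=O)[C@H]1OC(n2cnc3c(N)ncnc32)[C@H](O)[C@@H]1O` gives 19 nM, compound 2 `CCCCCCCCNC(=O)[C@H]1OC(n2cnc3c(N)ncnc32)[C@H](O)[C@@H]1O` gives 21 nM, and compound 3 `CCCCCCCCCCCNC(=O)[C@H]1OC(n2cnc3c(N)ncnc32)[C@H](O)[C@@H]1O` gives 123 nM, the highest of the three numbers. The unmeasured compound 4 `CC(=O)NCCCCCCCCNC(=O)[C@H]1OC(n2cnc3c(N)ncnc32)[C@H](O)[C@@H]1O` differs from compound 3 by acetamido in place of propyl on a saturated chain carbon, eight bonds along the chain from an amide-type nitrogen. Within the data shown here, two steps bear on this place: a 1.1-fold higher number from compound 1 to compound 2 (0.04 log units; within the scatter), and a 5.9-fold higher number from compound 2 to compound 3 (0.77 log units; beyond the scatter); the longer chain of compound 3 goes with a higher number, while compound 4 keeps the chain length of compound 2 and carries acetamido at that place. An expected step of a 3.1-fold lower number from compound 3 to compound 4 (0.49 log units; beyond the scatter) therefore seems reasonable, toward a lower number. Compound 4 is estimated at 40 nM, within a range from 10 nM to 160 nM.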

Compound 4, inhibition constant: 10 nM
The estimate for compound 4 lay 4.0-fold (0.60 log units) above the measured number, within the range that was stated.
By their numbers in this assay, from the lowest: compounds 4, 1 and 2 (each within the scatter of the next, the first and the last beyond it); then compound 3.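

In this assay, acetamido in place of propyl gives a 12-fold lower number from compound 3 to compound 4 (1.09 log units; beyond the scatter), and acetamido in place of hydrogen gives a 2.1-fold lower number from compound 2 to compound 4 (0.32 log units; beyond the scatter). With 2-acetamidoethyl in place of hydrogen, the result is a 1.9-fold lower number from compound 1 to compound 4 (0.28 log units; within the scatter), a step within the scatter. So at this place, added atoms need not go with a higher number, as the pentyl and propyl steps to compound 3 might have suggested. The compounds shown leave open how an amine or a carboxylic acid at the same chain end, or acetamido on a longer chain, would read. Nothing measured here gives a reason for these steps.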